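The source may report more compounds than this note shows. Statements on the series, on what has been measured and on what is new or still open speak of the compounds shown alone.

In an assay on isolated protein for displacement of a labelled ligand from Bile acid receptor (Homo sapiens), read by scintillation proximity assay and radioligand binding (a lower number here means a stronger inhibitor, a higher number a weaker inhibitor), compound 1 `O=C(O)c1cccc(NC(=O)C(C2CCCCC2)n2c(-c3ccc(Cl)cc3)nc3cc(F)c(F)cc32)c1` gives 1300 nM, and compound 2 `Cc1nc(NC(=O)C(C2CCCCC2)n2c(-c3ccc(Cl)cc3)nc3cc(F)c(F)cc32)sc1C(=O)O` gives 90 nM, the lowest of the two numbers. Going by the values given here, the only measured step, a 14-fold lower number from compound 1 to compound 2 (1.16 log units; beyond the scatter), exchanged the whole carboxy-bearing aromatic ring on the amide nitrogen. Compound 3 `O=C(O)c1ccc(NC(=O)C(C2CCCCC2)n2c(-c3ccc(Cl)cc3)nc3cc(F)c(F)cc32)nc1` differs from compound 2 by 5-carboxypyridin-2-yl in place of 5-carboxy-4-methyl-1,3-thiazol-2-yl on an amide-type nitrogen, again an exchange of that ring, moving from a five-membered aromatic ring with 2 hetero atoms back to a six-membered aromatic ring, the ring size seen in compound 1. For compound 3 a partial reversal of that large step is expected, a 3.9-fold higher number from compound 2 to compound 3 (0.59 log units; beyond the scatter). Compound 3 is estimated at 350 nM, range 100 nM to 1300 nM.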

Compound 3, half-maximal inhibitory concentration: 200 nM
Estimate against measurement, compound 3: 1.8-fold (0.24 log units) above; low and high end bracket the measured number.
By their numbers in this assay, from the lowest: compound 2; then compound 3; then compound 1.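

Exchanging the ring on the amide-type nitrogen gains potency without a five-membered ring: 5-carboxypyridin-2-yl, a six-membered aromatic ring like 3-carboxyphenyl, gives (a 6.5-fold lower number from compound 1 to compound 3 (0.81 log units; beyond the scatter)) in this assay. The six-membered ring still falls short of 5-carboxy-4-methyl-1,3-thiazol-2-yl (a 2.2-fold higher number from compound 2 to compound 3 (0.35 log units; beyond the scatter)), so ring size alone does not set the number. No measurement available here accounts for either step.

Still open, as far as these compounds go, is whether the gap to compound 2 follows the methyl group or the thiazole ring itself. Also open, from the compounds shown here alone, is how a primary amide or a tetrazole would serve in place of the carboxylic acid.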